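Methoxy Addition in a Cytotoxicity Series of Purines

A few compounds are considered here, and "the series" means these few. Any claim that something is new, unique, unknown or untested is made for them only; others in the source may bear on it.

Measured so far:
compound 1 `COc1ccc(CNc2ncnc3c2ncn3C2CCCCO2)cc1` — > 100000 nM
compound 2 `COc1ccc(CNc2ncnc3c2ncn3C2CCCCO2)c(OC)c1` — > 25000 nM
compound 3 `COc1cccc(CNc2ncnc3c2ncn3C2CCCO2)c1` — > 100000 nM

In an ADME assay on MCF7 cells (Homo sapiens) for cytotoxicity, with a stated time of 72 h (on this read-out higher numbers stand for weaker inhibition and lower numbers for stronger inhibition), compound 1 gives > 100000 nM, which is a limit of the assay and not a number. Compound 2 gives > 25000 nM, also a limit. Compound 3 gives > 100000 nM, again a limit. The change methoxy in place of hydrogen on an aromatic carbon therefore yields a step that the two limits leave unreadable from compound 1 to compound 2, unreadable because of the limit of > 100000 nM in this assay, at which 2 of the 3 values shown sit, and (the limit of > 25000 nM in this assay, at which 1 of the 3 values shown sits).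

Compound 4 `COc1ccc(OC)c(CNc2ncnc3c2ncn3C2CCCO2)c1` has not been measured. It differs from compound 3 by methoxy in place of hydrogen on an aromatic carbon, the same kind of change, though here the place is para rather than meta to a methoxy group. How the core of compound 3 differs from that of compound 1 is not broken down here.

Compound 4 is expected to give 100000 nM, a step of a number no higher from compound 3 to compound 4 (the limit leaves the size open). This expectation rests on compound 3 giving > 100000 nM and on (the limit of > 100000 nM in this assay, at which 2 of the 3 values shown sit).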

Compound 4, half-maximal inhibitory concentration: > 50000 nM
Compound 4 was reported as a limit; the forecaster's own chance of this, stated with the estimate: 85%; the middle value is on the limit's open side.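

Within the data shown here, compound 3 and compound 4 are both reported as limits, not numbers, so no step between them can be read. The compounds shown leave open whether methoxy in place of hydrogen on an aromatic carbon changes inhibition at all.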